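Amino in place of trifluoromethyl in the series

This account rests on a few compounds, and the source may have more. Where it says the series, first, only, none or still open, it means among the compounds named here.

In a functional assay on HCT-116 cells (Homo sapiens) for cytotoxicity, read by MTT assay, with a stated time of 48 h (on this read-out higher numbers stand for weaker inhibition of growth and lower numbers for stronger inhibition of growth), compound 1 `FC(F)(F)c1nc2cc(Cl)c(Cl)cc2n1CC1CC1` gives 61300 nM, compound 2 `FC(F)(F)c1nc2cc(Cl)c(Cl)cc2n1Cc1ccccc1` gives 8600 nM and compound 3 `FC(F)(F)c1cccc(Cn2c(C(F)(F)F)nc3cc(Cl)c(Cl)cc32)c1` gives 50500 nM. Compound 3 lies within the scatter of compound 1 and has a clearly higher number than compound 2. Compound 4 `Nc1cccc(Cn2c(C(F)(F)F)nc3cc(Cl)c(Cl)cc32)c1` carries amino in place of trifluoromethyl on an aromatic carbon, (amino in place of trifluoromethyl on an aromatic carbon). The closest measured step is a 5.9-fold higher number from compound 2 to compound 3 (0.77 log units; beyond the scatter), for trifluoromethyl in place of hydrogen on an aromatic carbon. The step of a 7.1-fold lower number from compound 1 to compound 2 (0.85 log units; beyond the scatter) bears only distantly. Among the measured compounds shown here, no measured step covers amino, so only a partial return towards compound 2 is assumed. The expected change is a 2.5-fold lower number from compound 3 to compound 4 (0.40 log units; beyond the scatter). Compound 4 is estimated at 20000 nM, with an expected range of 7000 nM to 60000 nM.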

Compound 4, concentration for 50% growth inhibition: 22600 nM
Estimate against measurement, compound 4: 1.1-fold (0.05 log units) below; the measured number falls inside the stated range.
By their numbers in this assay, from the lowest: compound 2; then compound 4; then compounds 3 and 1 (each within the scatter of the next).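

On the aromatic carbon meta to a large group, the number depends on the group and not only on whether the carbon is substituted: amino in place of trifluoromethyl gives a 2.2-fold lower number from compound 3 to compound 4 (0.35 log units; beyond the scatter). The recovery is partial, with amino still showing a 2.6-fold higher number from compound 2 to compound 4 (0.42 log units; beyond the scatter), although compound 4 stays clear of the cyclopropyl compound, with a 2.7-fold lower number from compound 1 to compound 4 (0.43 log units; beyond the scatter). Nothing at hand explains these differences.

Open, going by these compounds, is whether methoxy, fluorine or a carboxylic acid on this carbon would come closer to compound 2 than amino does. Also open, on these data alone, is whether an acetamide there would keep the number of compound 4.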